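Methyl placement on the hydroxyphenyl ring of compound 1

The compounds below may be only part of what the source reports. "The series", "measured", "known", "first", "only" and "open" are said of these compounds alone.

Compound 1 `Cc1ccc(/C=N/c2ccc(OCc3ccccc3)cc2)c(O)c1` is known in a functional assay, with a stated time of 30 min (on this read-out lower numbers stand for stronger inhibition and higher numbers for weaker inhibition), only through a limit: compound 1 gives > 200000 nM, a limit of the assay rather than a number. Compound 3 `COc1ccc(/C=N/c2ccc(OCc3ccccc3)cc2)c(O)c1` likewise gives > 200000 nM, again a limit. Compound 2 `Oc1ccc(/C=N/c2ccc(OCc3ccccc3)cc2)c(O)c1O` gives 43400 nM. The step that the two limits leave unreadable from compound 1 to compound 3 thus cannot be sized, because two of the three values rest at the limit of > 200000 nM in this assay, at which 2 of the 3 values shown sit. Compound 4 `Cc1ccc(O)c(/C=N/c2ccc(OCc3ccccc3)cc2)c1` differs from compound 1 by 2-hydroxy-5-methylphenyl in place of 2-hydroxy-4-methylphenyl on a carbon with a double bond to nitrogen. Among the compounds with values here, no measured step alters this place, so the expectation for compound 4 rests on the limit of compound 1 alone, and a limit is again the likeliest outcome. Compound 4 is estimated at 200000 nM, within 80000 nM to 500000 nM. The expected step of a number no higher from compound 1 to compound 4 (the limit leaves the size open) is none beyond the scatter.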

Compound 4, half-maximal inhibitory concentration: > 200000 nM
Compound 4 was reported as a limit (the forecaster's own chance of this, stated with the estimate: 70%); the middle value sits exactly at the limit.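

Compound 1 and compound 4 both rest at a limit in this assay, so the step between them cannot be read: the limit of > 200000 nM in this assay, at which 3 of the 4 values shown sit.

The compounds shown leave open whether 2-hydroxy-5-methylphenyl in place of 2-hydroxy-4-methylphenyl changes inhibition at all.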